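The source may report more compounds than this note shows. Statements on the series, on what has been measured and on what is new or still open speak of the compounds shown alone.

Measured so far in a functional assay on SGC-7901 cells (Homo sapiens) for antiproliferative activity, read by MTT assay, with a stated time of 24 h; on this read-out lower numbers stand for stronger inhibition and higher numbers for weaker inhibition
- compound 1 `O=C(NNc1ccccc1Cl)c1ccc(NS(=O)(=O)c2cnc(O)nc2O)cc1` gives 3630 nM
- compound 2 `Cc1ccccc1NNC(=O)c1cccc(NS(=O)(=O)c2cnc(O)nc2O)c1` gives > 20000 nM, which is a limit
- compound 3 `O=C(NNc1cccc(Cl)c1)c1cccc(NS(=O)(=O)c2cnc(O)nc2O)c1` gives 11800 nM

Compound 1 holds the lower of the two actual numbers, compound 3 is nearest to it with a higher number, and the remaining entry is only a limit.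

The next step leads to compound 4 `Cc1ccccc1C(=O)NNC(=O)c1ccc(NS(=O)(=O)c2cnc(O)nc2O)cc1`, with the change ((2-methylphenyl)carbonyl in place of 2-chlorophenyl on an amine nitrogen). In words, (2-methylphenyl)carbonyl stands in place of 2-chlorophenyl on an amine nitrogen, so that (2-chlorophenyl)amino becomes ((2-methylphenyl)carbonyl)amino.

Among the compounds with values here, one measured step bears on a change at this nitrogen: an at least 1.6-fold lower number from compound 2 to compound 3 (0.22 log units; that floor lies within the scatter). It exchanges one substituted phenyl group for another and brings in no carbonyl, so it sets no firm size for the present change. Within the data shown here, a move to a higher number is expected, resting only on compound 1 having the lowest number so far, against compound 3 at 11800 nM in the same series. The expected step is a 2.2-fold higher number from compound 1 to compound 4 (0.34 log units; beyond the scatter), and this expectation is loose. For compound 4 the estimate is 8000 nM, with an expected range from 2500 nM to 20000 nM in this assay.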

Compound 4, half-maximal inhibitory concentration: > 20000 nM
Compound 4: only a limit was reported; the forecaster's own chance of this, stated with the estimate: 20%; middle value at least 2.5-fold (0.39 log units) from the limit.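

In this assay compound 4 gives > 20000 nM, which is a limit and not a number. On an amine nitrogen whose other neighbour is an amide-type nitrogen, (2-methylphenyl)carbonyl in place of 2-chlorophenyl gives an at least 5.5-fold higher number from compound 1 to compound 4 (0.74 log units; beyond the scatter). Within the data shown here, this is the first step at this nitrogen that brings in a carbonyl and the first there that reads beyond the scatter, so ((2-methylphenyl)carbonyl)amino does not stand in for (2-chlorophenyl)amino on the core of compound 1 in this read-out. The step is a floor only, and the read-out sets no upper size for it: the limit of > 20000 nM in this assay, at which 2 of the 4 values shown sit.

The change joins two differences, the added carbonyl and a methyl on the ring in place of chlorine, and the compounds shown do not separate them; a (2-chlorophenyl)carbonyl group would bear directly on this. Also open, as far as these compounds go, is how a group without an aromatic ring at this nitrogen, such as acetyl or a longer alkyl chain, would read in this assay.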